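The source may hold more compounds than are shown below. What is called first, only, known or untested is meant among the compounds shown, and "the series" means these compounds.

Measured so far in a functional assay on MCF7 cells (Homo sapiens) for cytotoxicity; a lower number here means a stronger inhibitor, a higher number a weaker inhibitor:
- compound 1 `C=C/C=C\[C@H](C)[C@H](OC(N)=O)[C@@H](C)[C@H](O)[C@@H](C)C/C(C)=C\[C@H](C)[C@@H](O)[C@@H](C)/C=C\CCc1ccc(C)c(F)c1`: 1000 nM
- compound 2 `C=C/C=C\[C@H](C)[C@H](OC(N)=O)[C@@H](C)[C@H](O)[C@@H](C)C/C(C)=C\[C@H](C)[C@@H](O)[C@@H](C)/C=C\CCc1cccc(F)c1`: 370 nM
- compound 3 `C=C/C=C\[C@H](C)[C@H](OC(N)=O)[C@@H](C)[C@H](O)[C@@H](C)C/C(C)=C\[C@H](C)[C@@H](O)[C@@H](C)/C=C\CCc1cccc(O)c1C`: 490 nM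

Compound 3, at 490 nM, stands close to one of the other two compounds and apart from the other: a 1.3-fold higher number from compound 2 to compound 3 (0.12 log units; within the scatter), whereas a 2.0-fold lower number from compound 1 to compound 3 (0.31 log units; beyond the scatter). Compound 4 `C=C/C=C\[C@H](C)[C@H](OC(N)=O)[C@@H](C)[C@H](O)[C@@H](C)C/C(C)=C\[C@H](C)[C@@H](O)[C@@H](C)/C=C\CCc1ccc(C)c(O)c1` is the next to be tested, and it has the same atoms as compound 3, joined differently: 3-hydroxy-4-methylphenyl in place of 3-hydroxy-2-methylphenyl on a saturated chain carbon, two bonds along the chain from a double-bonded chain carbon.

Among the compounds with values here, no measured step makes this exact change, so the evidence is indirect. The closest guide is a 2.7-fold lower number from compound 1 to compound 2 (0.43 log units; beyond the scatter), where hydrogen takes the place of methyl on an aromatic carbon. Compound 4 keeps the methyl where compound 1 has it, which points towards a somewhat higher number in this assay. The steps among these three compounds are all small, so only a small move is expected, and it may not clear the scatter. The expected change is a 1.4-fold higher number from compound 3 to compound 4 (0.15 log units; within the scatter). For compound 4 the estimated value is 700 nM, with an expected range of 250 nM to 2000 nM.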

Compound 4, half-maximal inhibitory concentration: 770 nM
Beside the measured number, compound 4's estimate is 1.1-fold (0.04 log units) below it, within the range that was stated.
By their numbers in this assay, from the lowest: compounds 2, 3, 4 and 1 (each within the scatter of the next, the first and the last beyond it).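

In this assay exchanging 3-hydroxy-2-methylphenyl for 3-hydroxy-4-methylphenyl gives a 1.6-fold higher number from compound 3 to compound 4 (0.20 log units; within the scatter) and so does not separate the two groups, and with the methyl kept, hydroxy in place of fluoro gives a 1.3-fold lower number from compound 1 to compound 4 (0.11 log units; within the scatter) and does not separate those two either. Within the data shown here, the one new step that clears the scatter, modestly, is a 2.1-fold higher number from compound 2 to compound 4 (0.32 log units; beyond the scatter) so compound 1 and compound 4, both 4-methylphenyl compounds, stand apart from the 3-fluorophenyl of compound 2, while compound 3 does not. No measurement here accounts for these steps.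

As far as these compounds go, whether an amine or a carboxylic acid in place of the hydroxy would fit this pattern remains open. So does the effect of a longer chain than the 2-arylethyl one on the same carbon.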